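The source may report more compounds than this note shows. Statements on the series, on what has been measured and on what is new or still open speak of the compounds shown alone.

Measured compounds in a functional assay on MCF7 cells (Homo sapiens) for inhibition, read by sulforhodamine B assay; on this read-out lower numbers stand for stronger inhibition and higher numbers for weaker inhibition:
Compound 1 `O=C1C=C(NC2CCCCC2)C(=O)c2c1nc1n2[C@H]2OC[C@@H](O)[C@H]2OC1` gives > 8000 nM, which is a limit of the assay and not a number.
Compound 2 `O=C1C(Nc2ccc(C(F)(F)F)cc2)=CC(=O)c2c1nc1n2[C@H]2OC[C@@H](O)[C@H]2OC1` gives > 4000 nM, again a limit rather than a number.
Compound 3 `O=C1C(NC2CCCCC2)=CC(=O)c2c1nc1n2[C@H]2OC[C@@H](O)[C@H]2OC1` gives > 16000 nM, once more a limit only.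

All three values therefore sit at limits: the limit of > 16000 nM in this assay, at which 1 of the 3 values shown sits, the limit of > 4000 nM in this assay, at which 1 of the 3 values shown sits, and (the limit of > 8000 nM in this assay, at which 1 of the 3 values shown sits). Compound 1 cannot be placed relative to compound 2 or compound 3 on these numbers, since none of them is a measured value. Among the measured compounds shown here, the one single-point comparison among the measured compounds, a step that the two limits leave unreadable from compound 2 to compound 3, changes cyclohexyl for 4-(trifluoromethyl)phenyl on an amine nitrogen, and its size is not readable.

Compound 4 `COc1cccc(NC2=CC(=O)c3nc4n(c3C2=O)[C@H]2OC[C@@H](O)[C@H]2OC4)c1` differs from compound 1 by 3-methoxyphenyl in place of cyclohexyl on an amine nitrogen. For the measured compounds named here, the closest precedent is the step between compound 2 and compound 3, where an aromatic group on the amine nitrogen also stands against cyclohexyl, but that step yields no readable size, so it gives no direction for this assay. Going by the values given here, no measured step within this set bears readably on the change. The expectation for compound 4 therefore rests on the fact that every measured analogue reached only a limit.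

Compound 4 is thus expected to give about 10000 nM in this assay, within a range from 2500 nM to 40000 nM. The expected step is accordingly a step that the limit leaves unreadable from compound 1 to compound 4, meaning no readable change.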

Compound 4, half-maximal inhibitory concentration: > 4000 nM
Compound 4: no number, only a limit; the forecaster's own chance of this, stated with the estimate: 75%; the middle value lies beyond the limit too.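

In this assay compound 4 gives > 4000 nM, which is a limit and not a number. Compound 1 also stands only at a limit, and the step between compound 1 and compound 4 cannot be read. The compounds shown leave open how strongly any of them inhibits, and whether 3-methoxyphenyl in place of cyclohexyl on an amine nitrogen changes that inhibition at all.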